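Sulfamoyl to Methylsulfonyl on a Piperidine Tail

This account rests on a few compounds, and the source may have more. Where it says the series, first, only, none or still open, it means among the compounds named here.

Compound 1, `Cc1cc(/C=C/C#N)cc(C)c1Oc1nc(Nc2ccc(CN3CCN(S(C)(=O)=O)CC3)cc2)nc2sccc12`, was tested in an ADME assay on MT4 cells (Homo sapiens) for cytotoxicity, read by MTT assay, with a stated time of 5 days (a higher number here means that more compound is tolerated, a lower number that less compound is tolerated), where compound 1 gives 131000 nM. Compound 2, `Cc1cc(/C=C/C#N)cc(C)c1Oc1nc(Nc2ccc(N3CCCC(NS(N)(=O)=O)C3)cc2)nc2sccc12`, carries 3-(sulfamoylamino)piperidin-1-yl in place of (4-(methylsulfonyl)piperazin-1-yl)methyl on an aromatic carbon. In this assay compound 2 reaches only a limit, > 217000 nM, and no number. The step of an at least 1.6-fold higher number from compound 1 to compound 2 (0.21 log units; that floor lies within the scatter) therefore rests on that limit, and compound 2 stands at the limit of > 217000 nM in this assay, at which 1 of the 2 values shown sits, the upper edge of what the two values show.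

Compound 3, `Cc1cc(/C=C/C#N)cc(C)c1Oc1nc(Nc2ccc(N3CCCC(NS(C)(=O)=O)C3)cc2)nc2sccc12`, differs from compound 2 by methyl in place of amino on a sulfonyl sulfur. For the measured compounds named here, the only measured step, an at least 1.6-fold higher number from compound 1 to compound 2 (0.21 log units; that floor lies within the scatter), exchanges the whole tail rather than the group on the sulfonyl sulfur, so it bears on the present change only loosely, and its floor lies within the scatter. The change from sulfamoyl to methylsulfonyl is thus expected to produce no step beyond the scatter in this assay, in either direction. The estimated change is an at least 1.0-fold lower number from compound 2 to compound 3 (0.03 log units; that floor lies within the scatter). Compound 3 is expected to give 200000 nM, with a range from 100000 nM to 400000 nM.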

Compound 3, half-maximal cytotoxic concentration: 112000 nM
Estimate against measurement, compound 3: 1.8-fold (0.25 log units) above; low and high end bracket the measured number.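

In this assay, for the compounds shown here, methyl in place of amino on the sulfonyl sulfur gives an at least 1.9-fold lower number from compound 2 to compound 3 (0.28 log units; that floor lies within the scatter), so the first comparison confined to this one group yields only a floor inside the scatter and no change that can be read in either direction. Compound 2 has only a limit here, so this step is a floor and nothing firmer: the limit of > 217000 nM in this assay, at which 1 of the 3 values shown sits. The other new step, a 1.2-fold lower number from compound 1 to compound 3 (0.07 log units; within the scatter), is a plain comparison of two numbers and places the 3-(methanesulfonamido)piperidin-1-yl tail within the scatter of the (4-(methylsulfonyl)piperazin-1-yl)methyl tail, whereas the earlier tail exchange rested on a limit and offered only a floor.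

On these data alone, whether the real value of compound 2 lies well past its limit, which would make the change from sulfamoyl to methylsulfonyl larger than its floor, remains open. Also open, as far as these compounds go, is how this assay responds to an ethyl or cyclopropyl group on the same sulfonyl sulfur, or to a carboxylic acid or an amine in place of the methanesulfonamido group on the piperidine.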